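A Chloro Swap on the 2-Fluorophenyl Group

This account rests on a few compounds, and the source may have more. Where it says the series, first, only, none or still open, it means among the compounds named here.

In a functional assay on PANC-1 cells (Homo sapiens) for inhibition, read by MTT assay, with a stated time of 24 h (on this read-out lower numbers stand for stronger inhibition and higher numbers for weaker inhibition), compound 2 (`CC1(C)[C@H]2CC[C@]1(C)N(Cc1cn(-c3ccccc3F)nn1)C(=O)C2`) gives 150 nM, and compound 1 (`CC1(C)[C@H]2CC[C@]1(C)N(Cc1cn(-c3ccc(C#N)cc3)nn1)C(=O)C2`) gives 250 nM. Among the measured compounds shown here, these two values lie within the scatter of each other, and the only measured step is a 1.7-fold lower number from compound 1 to compound 2 (0.22 log units; within the scatter). That step says little here, since it concerns a different swap. Compound 3 (`CC1(C)[C@H]2CC[C@]1(C)N(Cc1cn(-c3ccccc3Cl)nn1)C(=O)C2`) carries chloro in place of fluoro on an aromatic carbon. For the measured compounds named here, no measured step covers this change, so nothing beyond the scatter is expected in this assay. The expected step is a 1.1-fold higher number from compound 2 to compound 3 (0.03 log units; within the scatter). For compound 3 the estimated value is 160 nM, within an expected range of 60 nM to 420 nM.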

Compound 3, half-maximal inhibitory concentration: 270 nM
Estimate against measurement, compound 3: 1.7-fold (0.23 log units) below, within the range that was stated.
By their numbers in this assay, from the lowest: compounds 2, 1 and 3 (each within the scatter of the next).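

In this assay, chloro in place of fluoro on this aromatic carbon gives a 1.8-fold higher number from compound 2 to compound 3 (0.26 log units; within the scatter) so one halogen can replace the other here without a step that stands clear of the scatter. Likewise, 2-chlorophenyl in place of 4-cyanophenyl gives a 1.1-fold higher number from compound 1 to compound 3 (0.03 log units; within the scatter) and this swap on the aromatic nitrogen also shows nothing beyond the scatter. No supporting measurement is available to explain either result. On these data alone, whether an amine or a methoxy group on this carbon would give a step beyond the scatter remains open.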